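Azetidine oxadiazole series: amide replacement at the carbonyl

The compounds below may be only part of what the source reports. "The series", "measured", "known", "first", "only" and "open" are said of these compounds alone.

Measured compounds:
compound 1 `COC1CCCN(C(=O)N2CC(c3nc(-c4cccc(Cl)c4)no3)C2)C1` — 1830 nM
compound 2 `O=S(=O)(c1ccc(F)cc1)N1CC(c2nc(-c3cccc(Cl)c3)no2)C1` — 130 nM

In an assay on HEK293 cells for negative allosteric modulation of metabotropic glutamate receptor 5 (Homo sapiens), read by FLIPR (on this read-out higher numbers stand for weaker inhibition and lower numbers for stronger inhibition), compound 1 gives 1830 nM, the higher of the two numbers. Going by the values given here, compound 2 gives 130 nM, a number beyond the scatter below compound 1; the two structures differ in more than one place, so no single step is traced between them. Compound 3 `O=C(C1CCC1)N1CC(c2nc(-c3cccc(Cl)c3)no2)C1` differs from compound 1 by cyclobutyl in place of 3-methoxypiperidin-1-yl on a carbonyl carbon. Among the compounds with values here, no measured pair covers this change. The step of a 2.3-fold lower number from compound 1 to compound 3 (0.36 log units; beyond the scatter) is expected to be modest, toward a lower number, near the edge of the scatter. For compound 3 the estimate in this assay is 800 nM, within 250 nM to 2500 nM.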

Compound 3, half-maximal inhibitory concentration: 1500 nM
Compound 3: the middle estimate sits 1.9-fold (0.27 log units) below what was measured, and the stated range covers the measured number.
By their numbers in this assay, from the lowest: compound 2; then compounds 3 and 1 (each within the scatter of the next).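

In this assay, cyclobutyl in place of 3-methoxypiperidin-1-yl on a carbonyl carbon gives a 1.2-fold lower number from compound 1 to compound 3 (0.09 log units; within the scatter) and so does not separate the two groups at this position. This holds even though the entering group has fewer heavy atoms and no hydrogen-bond acceptor. Nothing available accounts for this result.

A phenyl ring or a dimethylamino group on the same carbonyl carbon remains untested in the compounds shown. Also open, as far as these compounds go, is whether any group there moves the number beyond the scatter.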